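The source may report more compounds than this note shows. Statements on the series, on what has been measured and on what is new or still open speak of the compounds shown alone.

Measured compounds:
compound 1 `COc1ccc(OCC2=NCCO2)cc1` gives 16.6% in a functional assay on the whole organism for inhibition, with Rattus norvegicus as the target, read by paw edema, with a stated time of 30 min, at a dose of 20 mg/kg by the oral route; a lower number here means a weaker effect, a higher number a stronger effect of the compound at the dose given
compound 2 `Clc1ccc(OCC2=NCCO2)cc1` gives 30.3% in this assay
compound 3 `Cc1cc(OCC2=NCCO2)ccc1Cl` gives 22.2% in this assay

Of the three numbers, compound 2 has the highest. Its separation from compound 3 is only a number 8.1 percentage points lower from compound 2 to compound 3 (within the scatter), which is within the scatter, so no order between those two can be claimed; its separation from compound 1 is a number 13.7 percentage points higher from compound 1 to compound 2 (beyond the scatter), which is beyond the scatter.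

Compound 4 `Fc1ccc(OCC2=NCCO2)cc1` differs from compound 2 by fluoro in place of chloro on an aromatic carbon. For the measured compounds named here, no measured step exchanges one halogen for another. Going by the values given here, the only step that bears on this position is a number 13.7 percentage points higher from compound 1 to compound 2 (beyond the scatter), a modest rise when chloro replaced methoxy, which shows that the group on this carbon matters and that chloro gave the highest number seen. With fluoro entering in place of chloro, a step of a number 7.3 percentage points lower from compound 2 to compound 4 (within the scatter) in this assay is expected, leaning toward a small loss, since compound 2 gave 30.3% and nothing shows fluoro matching it. Compound 4 is therefore estimated at 23%, within 10% to 36%.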

Compound 4, a percentage reported as inhibition, in the whole organism at one dose (the size of the read-out at that dose, not a potency): 18.5%
Estimate against measurement, compound 4: 4.5 percentage points above; measured number inside the range.
By their numbers in this assay, from the lowest: compounds 1, 4, 3 and 2 (each within the scatter of the next, the first and the last beyond it).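

In this assay, for the compounds shown here, the two halogens are not interchangeable on this carbon: fluoro in place of chloro gives a number 11.8 percentage points lower from compound 2 to compound 4 (beyond the scatter), the first measured exchange of one halogen for the other. Fluoro in place of methoxy gives a number 1.9 percentage points higher from compound 1 to compound 4 (within the scatter), so fluoro and methoxy cannot be told apart here, and the rise seen with chloro does not extend to fluoro. Nothing available explains why chloro and fluoro differ in this way.

Going by these compounds, it remains open whether bromo, an amine or a carboxylic acid on this carbon would stand with chloro or with fluoro and methoxy. These compounds also leave open whether the gap between chloro and fluoro would persist at another dose or time.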